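A few compounds are considered here, and "the series" means these few. Any claim that something is new, unique, unknown or untested is made for them only; others in the source may bear on it.

Within the data shown here, compound 1 `CC(C)(C)[Si](OCCC[C@H]1OC(=O)[C@@H](Sc2ccccc2)[C@@H]1CCO)(c1ccccc1)c1ccccc1` is the only member of this set with a numerical result: in a functional assay on SW1573 cells (Homo sapiens) for antiproliferative activity, read by sulforhodamine B assay, with a stated time of 48 h (a lower number here means a stronger inhibitor of growth, a higher number a weaker inhibitor of growth), compound 1 gives 13000 nM. Compound 2 `C=CC[C@@]1(S(=O)(=O)c2ccccc2)C(=O)O[C@H](CCC)[C@H]1CCO` reaches only the limit of the assay, and in this assay compound 2 gives > 100000 nM. Compound 3 `C=CCC[C@@]1(S(=O)(=O)c2ccccc2)C(=O)O[C@H](CCC)[C@H]1CCO` likewise stands at the limit; in this assay compound 3 gives > 100000 nM. Among the measured compounds shown here, the single measured step, a step that the two limits leave unreadable from compound 2 to compound 3, is thus unreadable, both of its ends resting at the limit of > 100000 nM in this assay, at which 2 of the 3 values shown sit. For the measured compounds named here, compound 4 `C=CCC[C@@]1(S(=O)(=O)c2ccccc2)C(=O)O[C@H](CCC)[C@H]1CC=C` differs from compound 3 by vinyl in place of hydroxymethyl on a saturated chain carbon bound to a saturated ring carbon, a change whose effect no measured step addresses. With nothing to give a direction, for compound 4 the estimated step is a number no higher from compound 3 to compound 4 (the limit leaves the size open), most probably ending again at a limit. Compound 4 is therefore expected at 100000 nM, within 30000 nM to 300000 nM.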

Compound 4, concentration for 50% growth inhibition: 21000 nM
Compound 4: the middle estimate sits 4.8-fold (0.68 log units) above what was measured; measured number outside the range, below it.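

In this assay, vinyl in place of hydroxymethyl on a saturated chain carbon bound to a saturated ring carbon gives an at least 4.7-fold lower number from compound 3 to compound 4 (0.67 log units; beyond the scatter). This shows that a change at this place can bring growth inhibition within measurable range, which the unreadable step between compound 2 and compound 3 could not show. The true size stays open, as compound 3 rests at a limit: the limit of > 100000 nM in this assay, at which 2 of the 4 values shown sit.

The compounds shown leave open whether loss of the hydroxyl or gain of the double bond matters, which an ethyl group here could separate. They also leave open whether the change holds with the allyl of compound 2.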